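The source may hold more compounds than are shown below. What is called first, only, known or untested is meant among the compounds shown, and "the series" means these compounds.

compound 1 `Cc1ccc(C(=O)CCN2CCN(c3ccc(C(F)(F)F)cc3)CC2)cc1`: 140000 nM
compound 2 `O=C(CCN1CCN(c2ccc(F)cc2)CC1)c1ccc(Cl)c(F)c1`: 105000 nM

In an ADME assay on Vero cells (Chlorocebus sabaeus) for cytotoxicity, read by resazurin assay, with a stated time of 72 h (on this read-out higher numbers stand for weaker inhibition and lower numbers for stronger inhibition), compound 2 gives 105000 nM and stands within the scatter of compound 1. Compound 3 `O=C(CCN1CCN(c2ccc(C(F)(F)F)cc2)CC1)c1ccc(Cl)c(F)c1` differs from compound 2 by trifluoromethyl in place of fluoro on an aromatic carbon with trifluoromethyl in place of fluoro on an aromatic carbon, para to a large group. For the measured compounds named here, no measured step isolates this change. Compound 1 also carries a trifluoromethyl and gives 140000 nM in the same range, so no step beyond the scatter is expected in this assay in either direction. The expected 1.1-fold higher number from compound 2 to compound 3 (0.06 log units; within the scatter) is therefore small. For compound 3 the estimated value is 120000 nM with an expected range from 60000 nM to 220000 nM on this read-out.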

Compound 3, half-maximal inhibitory concentration: 74300 nM
Compound 3: middle estimate off by 1.6-fold (0.21 log units), on the high side, and the stated range covers the measured number.
By their numbers in this assay, from the lowest: compounds 3, 2 and 1 (each within the scatter of the next).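

In this assay trifluoromethyl in place of fluoro on an aromatic carbon, para to a large group, gives a 1.4-fold lower number from compound 2 to compound 3 (0.15 log units; within the scatter) and so provides a measured step for this change, one that stays within the scatter. Replacing 4-methylphenyl with 4-chloro-3-fluorophenyl on a carbonyl carbon gives a 1.9-fold lower number from compound 1 to compound 3 (0.28 log units; within the scatter) and also stays within the scatter, so neither change separates these compounds on this read-out. No available measurement accounts for these results.

As far as these compounds go, whether an amine or a carboxylic acid on this aromatic carbon would give a step beyond the scatter remains open. So does the outcome for a methoxy group there.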